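The source may hold more compounds than are shown below. What is called first, only, known or untested is meant among the compounds shown, and "the series" means these compounds.

Measured so far:
Compound 1, `O=Cc1cn(-c2ccccc2)nc1-c1ccc([N+](=O)[O-])cc1`: 106%
Compound 2, `O=Cc1cn(-c2ccccc2)nc1-c1cccc([N+](=O)[O-])c1`: 89%

Of the compounds shown here, two have been tested in a functional assay on MCF7 cells (Homo sapiens) for antiproliferative activity, read by MTT assay, with a stated time of 24 h, tested at 0.0001 ug/mL; a higher number here means a weaker effect of the compound at the concentration tested, a lower number a stronger effect. Compound 1, with a nitro group, gives 106%, the higher of the two numbers, which at the tested concentration means essentially no slowing of cell growth. Compound 2 lies lower by a gap beyond the usual scatter, and that is all these two values show.

Compound 3, `O=Cc1cn(-c2ccccc2)nc1-c1ccc(Cl)cc1`, has not yet been measured. It differs from compound 1 in one place: chloro in place of nitro on an aromatic carbon. Going by the values given here, no step between two measured compounds mirrors this exchange, so the guide is compound 1 alone. Because compound 1 gives 106%, a reading already at the inactive end, the step expected from the exchange is a number 8 percentage points lower from compound 1 to compound 3 (within the scatter), a change within the scatter in either direction. Compound 3 is therefore estimated at 98%, with a range from 82% to 114%.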

Compound 3, a percentage reported as activity, at one concentration (the size of the read-out at that concentration, not a potency): 100%
Beside the measured number, compound 3's estimate is 2 percentage points below it, within the range that was stated.
By their numbers in this assay, from the lowest: compound 2; then compounds 3 and 1 (each within the scatter of the next).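

At this position on the ring, putting chloro in place of nitro gives a number 6 percentage points lower from compound 1 to compound 3 (within the scatter) in this assay. A nitro group of three heavy atoms with two hydrogen-bond acceptors can therefore give way to a single chlorine atom without a reading that stands apart, and compound 3 , at 100%, shows no slowing of cell growth at this concentration. Nothing at hand bears on why these two groups read alike.

On these data alone, whether an amine, a carboxylic acid or a longer chain at this same place would move the reading remains open. Also open, as far as these compounds go, is whether the nitro and chloro compounds would still read alike at a higher concentration, where cell growth might actually slow, since a single very low concentration cannot show this.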